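A few compounds are considered here, and "the series" means these few. Any claim that something is new, unique, unknown or untested is made for them only; others in the source may bear on it.

Measured so far, in a functional assay (muscle tissue) with Cavia porcellus as the target; on this read-out lower numbers stand for an effect already at smaller amounts and higher numbers for an effect only at larger amounts of compound:
compound 1 `COC(=O)C1=C(C)N=C(C)/C(=C(\O)OC)C1c1cc([N+](=O)[O-])ccc1O`, 100 nM
compound 2 `COC(=O)C1=C(C)N=C(C)/C(=C(\O)OC)C1c1ccc(I)cc1`, 22900 nM
compound 3 `COC(=O)C1=C(C)N=C(C)/C(=C(\O)OC)C1c1ccccc1N`, 39800 nM

Compound 3 stands at the highest number of the three. Its nearest neighbour is compound 2, and the step of a 1.7-fold higher number from compound 2 to compound 3 (0.24 log units; within the scatter) lies within the usual scatter, so the two cannot be told apart. Going by the values given here, compound 1, which carries a 4-nitro and a 2-hydroxy group on its phenyl ring, sits far lower, beyond the scatter, and is the only compound of the three with a low number.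

Compound 4 `COC(=O)C1=C(C)N=C(C)/C(=C(\O)OC)C1c1cc(Cl)cc(Cl)c1` has not yet been measured. It differs from compound 3 as follows: 3,5-dichlorophenyl in place of 2-aminophenyl on a saturated ring carbon. Among the compounds with values here, the one measured step that bears on it is the exchange of one phenyl substitution pattern for another, from compound 2 to compound 3, and that step stayed within the scatter. Within the data shown here, there is no measured compound with a dichlorophenyl group, and the aryl groups of compounds 2 and 3 gave similar numbers while only compound 1 broke away.

Compound 4 is therefore expected to stay close to compounds 2 and 3, with the step of a 2.7-fold lower number from compound 3 to compound 4 (0.42 log units; beyond the scatter) estimated to fall within or near the scatter. The estimate for compound 4 in this assay is 15000 nM, in the range 3000 nM to 70000 nM.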

Compound 4, half-maximal effective concentration: 93.3 nM
Estimate against measurement, compound 4: 160-fold (2.21 log units) above, and the stated range ends above it.
By their numbers in this assay, from the lowest: compounds 4 and 1 (each within the scatter of the next); then compounds 2 and 3 (each within the scatter of the next).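

The aryl group on this saturated ring carbon can move the number in this assay a long way, which the earlier exchange of aryl groups within the scatter did not reveal: 3,5-dichlorophenyl in place of 2-aminophenyl gives a large step (a 430-fold lower number from compound 3 to compound 4 (2.63 log units; beyond the scatter)), and in place of 4-iodophenyl another large one (a 250-fold lower number from compound 2 to compound 4 (2.39 log units; beyond the scatter)). Compound 4 lies within the scatter of compound 1, so a low number here does not depend on the nitro and hydroxy groups that compound 1 carries. Nothing measured on these compounds accounts for the size of these steps.

The compounds shown leave open whether a phenyl ring bearing a single chlorine would keep the low number, or whether bromine or methyl groups could replace the two chlorines. They also leave open what an unsubstituted phenyl ring would give.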